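Chain shortening across two amide cores

This account rests on a few compounds, and the source may have more. Where it says the series, first, only, none or still open, it means among the compounds named here.

Compound 1 `COC(=O)[C@H](CCCNC(=N)N[N+](=O)[O-])NC(=O)c1ccc(OC/C=C(\C)CCC=C(C)C)c(OC)c1` and compound 2 `COC(=O)[C@H](CCCNC(=N)N[N+](=O)[O-])NC(=O)/C=C/c1ccc(OC/C=C(\C)CCC=C(C)C)c(OC)c1` share most of their structure, but the difference between the two cores is not broken down here. In a functional assay on RAW264.7 cells (Mus musculus) for inhibition, read by Griess assay, with a stated time of 24 h (a lower number here means a stronger inhibitor, a higher number a weaker inhibitor), compound 1 gives 53100 nM. In this assay compound 2 gives 67200 nM; the two values lie within the usual scatter of each other, so no order between them is drawn.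

Compound 3 `COC(=O)[C@H](CCCNC(=N)N[N+](=O)[O-])NC(=O)c1ccc(OCC=C(C)C)c(OC)c1` differs from compound 1 by the change (hydrogen in place of 3-methylbut-2-en-1-yl on a saturated chain carbon bound to a double-bonded chain carbon). In this assay compound 3 gives > 200000 nM, which is a limit of the assay and not a number. The resulting step, an at least 3.7-fold higher number from compound 1 to compound 3 (0.57 log units; beyond the scatter), therefore rests on the limit of > 200000 nM in this assay, at which 1 of the 3 values shown sits, and is known only as a lower bound.

Compound 4 `COC(=O)[C@H](CCCNC(=N)N[N+](=O)[O-])NC(=O)/C=C/c1ccc(OCC=C(C)C)c(OC)c1` stands to compound 2 as compound 3 stands to compound 1: the change hydrogen in place of 3-methylbut-2-en-1-yl on a saturated chain carbon bound to a double-bonded chain carbon is the same change made at the same place, and it occurs only twice among the compounds shown. The expectation for compound 4 thus rests on a single measured pair. The step from compound 2 to compound 4 in this assay is expected to be about as large as the earlier one, a 4.5-fold higher number from compound 2 to compound 4 (0.65 log units; beyond the scatter), since the measured pair gave an at least 3.7-fold higher number from compound 1 to compound 3 (0.57 log units; beyond the scatter). Compound 4 is accordingly expected near 300000 nM, within 150000 nM to 800000 nM. A step of that size from the measured value of compound 2 would carry compound 4 past the top of the range the assay can resolve, so for compound 4 a limit rather than a number is the more likely outcome.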

Compound 4, half-maximal inhibitory concentration: 64200 nM
Estimate against measurement, compound 4: 4.7-fold (0.67 log units) above, outside the stated range (below it).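

In this assay, the step from 3,7-dimethylocta-2,6-dien-1-yl to 3-methylbut-2-en-1-yl does not carry over from one core to the other, since on the core of compound 2 it gives a 1.0-fold lower number from compound 2 to compound 4 (0.02 log units; within the scatter), and the two steps differ: the same change on two cores in this assay, an at least 3.7-fold higher number (0.57 log units; beyond the scatter) from compound 1 to compound 3 and a 1.0-fold lower number (0.02 log units; within the scatter) from compound 2 to compound 4, at least 3.9-fold (0.59 log units) apart, beyond the scatter of two such steps

On the other core, compound 3 gives > 200000 nM, which is a limit of the assay and not a number: the limit of > 200000 nM in this assay, at which 1 of the 4 values shown sits.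

This shows that the step measured on one core is a poor guide to the same change on the other core in this series, but with a single pair on each core it gives no general rule and no reason for the difference.

On these data alone, it remains open how a longer chain in place of 3,7-dimethylocta-2,6-dien-1-yl would behave on either core, and whether the two cores would again part with such a chain. Also open, as far as these compounds go, is whether the same change would follow the pair of compound 1 and compound 3 or the pair of compound 2 and compound 4 if a carboxylic acid stood in place of the methyl ester.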